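This account rests on a few compounds, and the source may have more. Where it says the series, first, only, none or still open, it means among the compounds named here.

Measured so far in an ADME assay on the whole organism (Rattus norvegicus) for pharmacokinetics; a higher number here means that more of the compound sits outside the plasma, a lower number that more of the compound stays in the plasma:

- compound 1 `Cc1ncccc1-c1cnc(NCc2c(F)ccc3c2CCO3)c2cn[nH]c(=O)c12`: "not determined" (no result reported)
- compound 2 `CNC(=O)c1ccc(-c2cnc(NCc3c(F)ccc4c3CCO4)c3cn[nH]c(=O)c23)c(C)n1`: 2.7 L/kg

Among the measured compounds shown here, compound 2 is the only compound with a number in this assay, so it cannot yet be ranked against anything. The next compound, compound 3 `Cc1nc(C(=O)N(C)C)ccc1-c1cnc(NCc2c(F)ccc3c2CCO3)c2cn[nH]c(=O)c12`, keeps the shared core and changes one group, with methylcarbamoyl becoming dimethylcarbamoyl. The counted difference is methyl in place of hydrogen on an amide-type nitrogen, a methyl in place of hydrogen on an amide-type nitrogen. For the measured compounds named here, no measured pair shows this change, so the data give no direct guide to its size. In this assay a step no larger than the usual scatter is expected, with no firm direction, and this rests on compound 2 at 2.7 L/kg alone. The expected change is a 1.1-fold lower number from compound 2 to compound 3 (0.05 log units; within the scatter). For compound 3 the estimated value is 2.4 L/kg, within an expected range of 1.3 L/kg to 4.5 L/kg.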

Compound 3, volume of distribution at steady state: 1.9 L/kg
Beside the measured number, compound 3's estimate is 1.3-fold (0.10 log units) above it, within the range that was stated.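

Among the compounds shown here, the pair gives the first reading of this position in this assay: replacing the amide hydrogen with methyl, so that methylcarbamoyl becomes dimethylcarbamoyl, produces a 1.4-fold lower number from compound 2 to compound 3 (0.15 log units; within the scatter), a step that does not separate the two compounds. At this amide-type nitrogen, then, a single methyl in place of hydrogen leaves the volume of distribution within the scatter in this one pair. No measurement available here bears on what lies behind the step.

Compound 1, which carries no carbamoyl group, gives "not determined" (no result reported), so the effect of the whole group cannot be read. Also open, going by these compounds, is whether a longer chain such as ethyl on the amide nitrogen, or a carboxylic acid or an amine in place of the carbamoyl group, would move the number beyond the scatter.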